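Working notes: taking the methyl off compound 1

This account rests on a few compounds, and the source may have more. Where it says the series, first, only, none or still open, it means among the compounds named here.

Values in a functional assay on NMC-797 cells (Homo sapiens) for antiproliferative activity, with a stated time of 48 h (on this read-out lower numbers stand for stronger inhibition and higher numbers for weaker inhibition), stand as follows
Compound 1 `CC1[C@@H](c2cccc([N+](=O)[O-])c2)O[C@@H](c2cccc([N+](=O)[O-])c2)O[C@@]12C=CC(=O)O2` gives 12000 nM
Compound 2 `O=C1C=C[C@]2(C[C@@H](c3cccc(C(F)(F)F)c3)O[C@@H](c3cccc(C(F)(F)F)c3)O2)O1` gives 30 nM
Compound 3 `O=C1C=C[C@]2(C[C@@H](c3ccccc3[N+](=O)[O-])O[C@@H](c3ccccc3[N+](=O)[O-])O2)O1` gives 64 nM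

Compound 1 has the highest number of the three and is the weakest, beyond the scatter from both others. Next comes compound 4 `O=C1C=C[C@]2(C[C@@H](c3cccc([N+](=O)[O-])c3)O[C@@H](c3cccc([N+](=O)[O-])c3)O2)O1`, which differs from it by hydrogen in place of methyl on a saturated ring carbon. For the measured compounds named here, no measured pair shows this change alone. Compound 2 at 30 nM and compound 3 at 64 nM also lack that methyl, though their aryl groups differ. A large fall in the number is therefore expected in this assay and not a step within the scatter. The expected size is a 200-fold lower number from compound 1 to compound 4 (2.30 log units; beyond the scatter) toward stronger inhibition. For compound 4 the estimated value is 60 nM with an expected range from 15 nM to 400 nM in this series.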

Compound 4, half-maximal inhibitory concentration: 47 nM
The estimate for compound 4 lay 1.3-fold (0.11 log units) above the measured number; measured number inside the range.
By their numbers in this assay, from the lowest: compounds 2, 4 and 3 (each within the scatter of the next, the first and the last beyond it); then compound 1.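

In this assay, for the compounds shown here, hydrogen in place of methyl on a saturated ring carbon gives a 260-fold lower number from compound 1 to compound 4 (2.41 log units; beyond the scatter) with the 3-nitrophenyl groups unchanged, the first reading of this change alone. A single methyl at this position, one heavy atom, therefore carries a large step in this pair. Nothing available explains the size of the step.

As far as these compounds go, whether an ethyl group, a hydroxyl or a fluorine on this carbon matches the methyl remains open. So does whether the methyl carries a similar step with other aryl groups.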